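Swapping an Isobutylamino Group for a Benzyloxy Group

The source may report more compounds than this note shows. Statements on the series, on what has been measured and on what is new or still open speak of the compounds shown alone.

Four close relatives of one shared core are considered here. Compound 1 `CC(C)CNc1nc(N)nc2c1ncn2/C=C1/CC1(CO)CO` carries an isobutylamino group, and in an ADME assay on MOLT-3 cells (Homo sapiens) for cytotoxicity, with a stated time of 7 days (a higher number here means that more compound is tolerated, a lower number that less compound is tolerated), compound 1 has no result recorded: "not determined" (no result reported). Compound 2 `CCCCNc1nc(N)nc2c1ncn2/C=C1/CC1(CO)CO` carries a butylamino group instead; in this assay compound 2 ends at a limit of the assay, > 20000 nM. Compound 3 `CCCSc1nc(N)nc2c1ncn2/C=C1/CC1(CO)CO` carries a propylsulfanyl group; in this assay compound 3 likewise ends at a limit, > 20000 nM. Within the data shown here, the one measured step, a step that the two limits leave unreadable from compound 2 to compound 3, therefore cannot be read, and the only evidence is the limit of > 20000 nM in this assay, at which 2 of the 3 values shown sit. Compound 4 `Nc1nc(OCc2ccccc2)c2ncn(/C=C3/CC3(CO)CO)c2n1` has not yet been measured. It differs from compound 1 by benzyloxy in place of isobutylamino on an aromatic carbon. Among the measured compounds shown here, no measured step matches this change, so no direction can be given for this assay, and what can be said rests only on the limits already described. Compound 4 is therefore expected to show 30000 nM, with a range from 8000 nM to 100000 nM. The measurement itself will settle the matter.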

Compound 4, half-maximal cytotoxic concentration: > 20000 nM
Compound 4: only a limit was reported (the forecaster's own chance of this, stated with the estimate: 75%); the middle value does not contradict the limit.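

In this assay compound 4 gives > 20000 nM, which is a limit and not a number. The steps to compound 4 from compound 2 and compound 3 therefore cannot be read: the limit of > 20000 nM in this assay, at which 3 of the 4 values shown sit.

The compounds shown leave open whether swapping these groups changes how much compound is tolerated.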